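Thioether-linked quinazoline amides: a dichlorophenyl swap

The source may hold more compounds than are shown below. What is called first, only, known or untested is meant among the compounds shown, and "the series" means these compounds.

Measured so far:
compound 1 `O=C(CSc1nc(Nc2ccccc2)c2ccccc2n1)Nc1ccc(Cl)cc1Cl` — 9110 nM
compound 2 `C=CC(=O)Nc1cccc(NC(=O)CSc2nc(Nc3cccc(C)c3)c3ccccc3n2)c1` — 29200 nM

Both compounds have been run in a functional assay on PC-3 cells (Homo sapiens) for inhibition, read by MTT assay, with a stated time of 72 h; a lower number here means a stronger inhibitor, a higher number a weaker inhibitor. In this assay compound 1 gives 9110 nM and compound 2 gives 29200 nM; compound 2 stands at the higher of the two numbers, and the gap to compound 1 lies beyond the scatter of repeat runs. For the measured compounds named here, no pair of measured compounds differs in a single place, so no measured step is available to lean on.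

Compound 3 `C=CC(=O)Nc1cccc(NC(=O)CSc2nc(Nc3ccc(Cl)c(Cl)c3)c3ccccc3n2)c1` is not yet measured. It keeps the whole of compound 2 apart from one change: 3,4-dichlorophenyl in place of 3-methylphenyl on a nitrogen on an aromatic ring. The amide side bearing the acrylamide is untouched.

Compound 1 carries a dichlorophenyl as well, though on the other side of the molecule and with a different substitution, so it gives no direct guide. Going by the values given here, with no measured step for this change, the expectation is a modest shift, probably toward a lower number, but one that may well stay within the scatter. The step expected from compound 2 to compound 3 is a 1.9-fold lower number from compound 2 to compound 3 (0.29 log units; within the scatter). For compound 3 the estimate in this assay is 15000 nM, with a range from 5000 nM to 45000 nM.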

Compound 3, half-maximal inhibitory concentration: 27600 nM
The estimate for compound 3 lay 1.8-fold (0.26 log units) below the measured number, and the stated range covers the measured number.
By their numbers in this assay, from the lowest: compound 1; then compounds 3 and 2 (each within the scatter of the next).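

In this assay, for the compounds shown here, the change to 3,4-dichlorophenyl in place of 3-methylphenyl on a nitrogen on an aromatic ring gives a 1.1-fold lower number from compound 2 to compound 3 (0.02 log units; within the scatter) as the first measured single-place step. For this pair, then, the exchange of one aryl group for the other makes no readable difference, even though the methyl is replaced by two chlorine atoms and the amide side bearing the acrylamide stays fixed. Nothing available offers a reason for this flat step.

One step at one position cannot show whether the number at this nitrogen is insensitive to aryl substitution in general, as both groups here are carbon-only aromatic rings without hydrogen-bond donors or acceptors. Open questions are whether a phenyl ring carrying an amine or a carboxylic acid, or a longer chain ending in a morpholine in place of the aryl group, would move the number beyond the scatter, and whether the same exchange would read the same with a different group on the amide side.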